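A Methyl on the Outer Ring of Compound 3

A few compounds are considered here, and "the series" means these few. Any claim that something is new, unique, unknown or untested is made for them only; others in the source may bear on it.

Measured in a functional assay on 1321-N1 cells for agonist activity at Free fatty acid receptor 1 (Homo sapiens), read by calcium flux; a higher number here means that more compound is needed for the effect, a lower number that less compound is needed:
Compound 1, `O=C(O)CCc1ccc(NCc2ccccc2)cc1`, 759 nM
Compound 2, `O=C(O)CCc1ccc(NCc2cccc(Br)c2)cc1`, 174 nM
Compound 3, `O=C(O)CCc1ccc(NCc2cccc(-c3ccccc3)c2)cc1`, 53.7 nM

Compound 3 holds the lowest number of the three, with a 3.2-fold lower number from compound 2 to compound 3 (0.51 log units; beyond the scatter) and a 14-fold lower number from compound 1 to compound 3 (1.15 log units; beyond the scatter) both beyond the scatter, so it is the most potent of the measured set. Compound 4, `Cc1ccc(-c2cccc(CNc3ccc(CCC(=O)O)cc3)c2)cc1`, keeps the whole of compound 3 and adds (methyl in place of hydrogen on an aromatic carbon).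

Among the measured compounds shown here, no measured step touches the outer ring of the biphenyl, so none bears on this change directly. The measured steps all concern what replaces hydrogen on the inner benzyl ring: a 4.4-fold lower number from compound 1 to compound 2 (0.64 log units; beyond the scatter) and a 14-fold lower number from compound 1 to compound 3 (1.15 log units; beyond the scatter) show that a larger group there brought lower numbers, and a 3.2-fold lower number from compound 2 to compound 3 (0.51 log units; beyond the scatter) shows the same between bromo and phenyl. A methyl on the far ring is a much smaller addition than any of those. The account therefore expects only a small step in this assay for compound 4, at most a modest lowering and quite possibly one within the scatter, a 1.3-fold lower number from compound 3 to compound 4 (0.13 log units; within the scatter). Compound 4 is estimated at 40 nM, within a range from 15 nM to 120 nM.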

Compound 4, half-maximal effective concentration: 126 nM
For compound 4 the middle estimate is 3.2-fold (0.50 log units) below the measured one, outside the stated range (above it).
By their numbers in this assay, from the lowest: compound 3; then compounds 4 and 2 (each within the scatter of the next); then compound 1.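

In this assay the methyl on the outer ring is the first change among these compounds to raise the number: the step of a 2.3-fold higher number from compound 3 to compound 4 (0.37 log units; beyond the scatter) shows that the lowering seen as the group on the inner ring grew does not carry over to this carbon of the outer ring. Measured against bromo, the 4-methylphenyl group gives a 1.4-fold lower number from compound 2 to compound 4 (0.14 log units; within the scatter) and so no longer holds the advantage that phenyl held over bromo, although a single added carbon is all that separates it from phenyl. Measured against hydrogen, it still gives a 6.0-fold lower number from compound 1 to compound 4 (0.78 log units; beyond the scatter) and so keeps part of what phenyl gained over the unsubstituted benzyl ring, and nothing available here bears on why one methyl should give back that much.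

The compounds shown leave open whether the rise belongs to methyl in particular or to any group at this place on the outer ring, which a chlorine, a methoxy group or a hydroxyl group there could begin to separate. They also leave open whether a methyl on another carbon of the outer ring would move the number in the same direction.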